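The compounds below may be only part of what the source reports. "The series", "measured", "known", "first", "only" and "open" are said of these compounds alone.

Measured so far in a functional assay on HepG2 cells (Homo sapiens) for inhibition, read by sulforhodamine B assay, with a stated time of 72 h; a lower number here means a stronger inhibitor, a higher number a weaker inhibitor:
- compound 1 `C[C@H](Nc1ncnc2[nH]cnc12)c1nn(-c2cccnc2)c2cc(F)ccc12` - 37500 nM
- compound 2 `C[C@H](Nc1ncnc2[nH]cnc12)c1nn(-c2ccc(C#N)cc2)c2cc(F)ccc12` - 15100 nM
- compound 3 `C[C@H](Nc1ncnc2[nH]cnc12)c1nn(-c2cccc(S(C)(=O)=O)c2)c2cc(F)ccc12` - 14800 nM

Compound 3 sits at the low end of these numbers, level with compound 2 and clearly under compound 1. The next change gives compound 4 `C[C@H](Nc1ncnc2[nH]cnc12)c1nn(-c2cc(F)cc(F)c2)c2cc(F)ccc12`, with 3,5-difluorophenyl in place of 3-(methylsulfonyl)phenyl on an aromatic nitrogen.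

All three measured steps bear on this change, since each swaps the group on that same nitrogen. Two are modest, a 2.5-fold lower number from compound 1 to compound 2 (0.40 log units; beyond the scatter) and a 2.5-fold lower number from compound 1 to compound 3 (0.40 log units; beyond the scatter). The third, a 1.0-fold lower number from compound 2 to compound 3 (0.01 log units; within the scatter), lies within the scatter. Within the data shown here, none of the measured compounds carries fluorine on this group, so the data give no direct guide to the new substituent.

In this assay, no shift beyond the scatter is therefore expected, and neither direction is favoured. The expected step is a 1.1-fold lower number from compound 3 to compound 4 (0.02 log units; within the scatter). For compound 4 the estimate is 14000 nM, with an expected range of 5000 nM to 38000 nM.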

Compound 4, half-maximal inhibitory concentration: 22100 nM
The estimate for compound 4 lay 1.6-fold (0.20 log units) below the measured number, within the range that was stated.
By their numbers in this assay, from the lowest: compounds 3, 2, 4 and 1 (each within the scatter of the next, the first and the last beyond it).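

In this assay, 3,5-difluorophenyl on this aromatic nitrogen sits level with each of the other groups: a 1.5-fold higher number from compound 3 to compound 4 (0.17 log units; within the scatter), a 1.5-fold higher number from compound 2 to compound 4 (0.17 log units; within the scatter) and a 1.7-fold lower number from compound 1 to compound 4 (0.23 log units; within the scatter) all lie within the scatter. The position therefore tolerates an aryl group with no hydrogen-bond acceptors without a shift beyond the scatter from 3-(methylsulfonyl)phenyl or 4-cyanophenyl. Compound 4 also bridges the earlier gap between compound 1 and compounds 2 and 3, so these groups no longer fall into two separate levels. No measurement given here accounts for these values.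

Open, as far as these compounds go, is whether an amine or a carboxylic acid on the phenyl ring would move the number beyond the scatter. Also open, from the compounds shown here alone, is whether an alkyl chain in place of the aryl group on this nitrogen would do so.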